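Side-chain notes: from compound 3 to compound 4

The source may hold more compounds than are shown below. What is called first, only, known or untested is meant among the compounds shown, and "the series" means these compounds.

In a physicochemical assay for solubility, at pH 6.8 (on this read-out higher numbers stand for higher solubility and lower numbers for lower solubility), compound 1 (`CCC(=O)N[C@@H](C)c1ccc(NC(=O)[C@H]2C[C@@H]2c2cccnc2)cc1`) gives 54000 nM and compound 2 (`C[C@H](NC(=O)CC(F)(F)F)c1ccc(NC(=O)[C@H]2C[C@@H]2c2cccnc2)cc1`) gives 41000 nM, while compound 3 (`C[C@H](NC(=O)C1CCOCC1)c1ccc(NC(=O)[C@H]2C[C@@H]2c2cccnc2)cc1`) gives 90000 nM on the same read-out. Compound 3 is not separated from compound 1 but stands clear of compound 2. Compound 4 (`COCC(=O)N[C@@H](C)c1ccc(NC(=O)[C@H]2C[C@@H]2c2cccnc2)cc1`) differs from compound 3 by methoxymethyl in place of oxan-4-yl on a carbonyl carbon. The nearest evidence is the pair of steps joining open chains and oxan-4-yl at that carbon, namely a 1.7-fold higher number from compound 1 to compound 3 (0.22 log units; within the scatter) and a 2.2-fold higher number from compound 2 to compound 3 (0.34 log units; beyond the scatter) (both small, the second only modest). Read in reverse, they suggest a slight fall at most. The expected result is a 1.3-fold lower number from compound 3 to compound 4 (0.11 log units; within the scatter) in this assay with no move beyond the scatter. Compound 4 is estimated at 70000 nM with an expected range from 35000 nM to 130000 nM in this series.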

Compound 4, solubility: 520000 nM
Compound 4: the middle estimate sits 7.4-fold (0.87 log units) below what was measured; the whole stated range lies below it.
By their numbers in this assay, from the lowest: compounds 2, 1 and 3 (each within the scatter of the next, the first and the last beyond it); then compound 4.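

In this assay, among these compounds, the substituent on this carbonyl carbon proves able to move the number much further than the earlier compounds showed, with a 5.8-fold higher number from compound 3 to compound 4 (0.76 log units; beyond the scatter) for methoxymethyl in place of oxan-4-yl. Methoxy at the chain end gives a 9.6-fold higher number from compound 1 to compound 4 (0.98 log units; beyond the scatter) against methyl and a 13-fold higher number from compound 2 to compound 4 (1.10 log units; beyond the scatter) against trifluoromethyl, so methoxymethyl stands clear of both open chains and of the ring that also holds one oxygen. No evidence on hand accounts for this jump.

From the compounds shown here alone, whether the rise belongs to methoxymethyl alone remains open. Also open, going by these compounds, is how a longer ether chain such as 2-methoxyethyl or an amine such as dimethylaminomethyl would read on this carbonyl carbon.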